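The compounds below may be only part of what the source reports. "The series", "measured", "known", "first", "only" and "open" are said of these compounds alone.

In a functional assay on SK-MEL-28 cells (Homo sapiens) for cytotoxicity, read by MTT assay (a higher number here means a weaker inhibitor, a lower number a stronger inhibitor), the three measured compounds stand as follows.

Compound 1 `O=S(=O)(NCCCNc1nccc(-c2c(-c3cccc(F)c3)nc3sccn23)n1)c1ccc(F)cc1`: > 20000 nM, which is a limit of the assay (the limit of > 20000 nM in this assay, at which 1 of the 3 values shown sits).
Compound 2 `O=S(=O)(NCCNc1nccc(-c2c(-c3cccc(F)c3)nc3sccn23)n1)c1ccc(Br)cc1`: 13500 nM.
Compound 3 `O=S(=O)(NCCNc1nccc(-c2c(-c3cccc(F)c3)nc3sccn23)n1)c1ccc(Cl)cc1`: 18600 nM.

Compound 3 gives the highest of the two numbers reported. Its nearest neighbour is compound 2, and the step of a 1.4-fold higher number from compound 2 to compound 3 (0.14 log units; within the scatter) lies within the scatter, so the two cannot be put in order. The value of compound 1 is only a limit, and the steps of an at least 1.4-fold lower number from compound 1 to compound 2 (0.17 log units; that floor lies within the scatter) and an at least 1.0-fold lower number from compound 1 to compound 3 (0.03 log units; that floor lies within the scatter) are therefore floors, both of which sit within the scatter.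

Compound 4 `O=S(=O)(NCCNc1nccc(-c2c(-c3cccc(F)c3)nc3sccn23)n1)c1cccc(F)c1` has not yet been measured. It differs from compound 3 in one place: 3-fluorophenyl in place of 4-chlorophenyl on a sulfonyl sulfur. For the measured compounds named here, the only measured step that changes the halogen alone, a 1.4-fold higher number from compound 2 to compound 3 (0.14 log units; within the scatter), stayed within the scatter; the other two steps change the chain and the halogen together and rest on a limit. Going by the values given here, no measured pair puts a 3-fluorophenyl on the sulfonyl sulfur, so this change is untested here. The expectation is a step of a 1.0-fold lower number from compound 3 to compound 4 (0.01 log units; within the scatter), no movement beyond the scatter. Compound 4 is expected to give 18000 nM, between 8000 nM and 40000 nM, with a fair chance that only a limit is reported.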

Compound 4, half-maximal inhibitory concentration: 18300 nM
For compound 4 the middle estimate is 1.0-fold (0.01 log units) below the measured one, within the range that was stated.
By their numbers in this assay, from the lowest: compounds 2, 4 and 3 (each within the scatter of the next). At a limit, above all of these: compound 1.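

In this assay, the change from 4-chlorophenyl to 3-fluorophenyl on the sulfonyl sulfur alters both the halogen and its numbered ring position, unlike the change from bromo to chloro (a 1.4-fold higher number from compound 2 to compound 3 (0.14 log units; within the scatter)), yet the result stays within the scatter (a 1.0-fold lower number from compound 3 to compound 4 (0.01 log units; within the scatter)). The comparison with 4-bromophenyl gives the same reading (a 1.4-fold higher number from compound 2 to compound 4 (0.13 log units; within the scatter)), so these three halogenated phenyl groups cannot be put in order at this position. The value of compound 1 is a limit of the assay: the limit of > 20000 nM in this assay, at which 1 of the 4 values shown sits. The step that rests on this limit is only a floor (an at least 1.0-fold lower number from compound 1 to compound 4 (0.03 log units; that floor lies within the scatter)).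

The compounds shown leave open whether anything other than a halogenated phenyl on the sulfonyl sulfur, such as a phenyl ring carrying an amine or a carboxylic acid, would move the number in this assay beyond the scatter. They also leave the chain unresolved, as compound 1 differs from the others in both its chain and its sulfonyl aryl group, and a longer chain with 3-fluorophenyl held constant would be needed to examine the chain alone.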